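A few compounds are considered here, and "the series" means these few. Any claim that something is new, unique, unknown or untested is made for them only; others in the source may bear on it.

Compound 1 `CCN(CC)c1ccc(/C=N/NC(=O)CNC(=O)c2ccc(C#N)cc2)c(OCc2ccccc2Cl)c1` gives > 50000 nM as a limit
Compound 2 `COc1ccc(/C=N/NC(=O)CNC(=O)c2ccc(C)cc2)c(OCc2ccccc2Cl)c1` gives > 50000 nM as a limit

Both results come from a functional assay on HepG2 cells (Homo sapiens) for inhibition, read by MTT assay, with a stated time of 24 h (a lower number here means a stronger inhibitor, a higher number a weaker inhibitor), and neither is an exact number. A limit records only that the assay gave no exact value for that compound. Compound 2 therefore has no exact standing of its own, and the measured picture so far is the limit of > 50000 nM in this assay, at which 2 of the 2 values shown sit. With no exact values, the two compounds cannot be ranked against each other.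

Compound 3 `COc1ccc(/C=N/NC(=O)CNC(=O)c2ccc(C#N)cc2)c(OCc2ccccc2Cl)c1` is the next compound to consider. It has cyano in place of methyl on an aromatic carbon, para to a large group, so 4-methylphenyl becomes 4-cyanophenyl (cyano in place of methyl on an aromatic carbon). Among the compounds with values here, no measured pair shows what this change does. In this assay no shift beyond the usual scatter is expected, and another limit is the likeliest result. This expectation rests on compound 2, which gives the limit > 50000 nM in this test. The estimated change is a number no higher from compound 2 to compound 3 (the limit leaves the size open) and is expected to be small. For compound 3 the expected value is 50000 nM, with an estimated range from 20000 nM to 100000 nM.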

Compound 3, half-maximal inhibitory concentration: > 50000 nM
Compound 3: no number, only a limit; the forecaster's own chance of this, stated with the estimate: 75%; the middle value lies on the limit itself.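

In this assay compound 3 gives > 50000 nM, which is a limit and not a number. No step can be read from compound 1 or compound 2 to compound 3, as every result is a limit: the limit of > 50000 nM in this assay, at which 3 of the 3 values shown sit.

The compounds shown leave open whether cyano in place of methyl, or methoxy in place of diethylamino, changes the inhibition at all.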